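The source may report more compounds than this note shows. Statements on the series, on what has been measured and on what is new or still open speak of the compounds shown alone.

Measured in a functional assay on SK-MEL-28 cells (Homo sapiens) for inhibition; on this read-out higher numbers stand for weaker inhibition and lower numbers for stronger inhibition:
- compound 1 `COc1ccc(/C=C/c2ccc3ccccc3c2)cc1`: > 5000 nM (a limit)
- compound 2 `FC(F)(F)c1ccc(/C=C/c2ccc3ccccc3c2)cc1`: > 5000 nM (a limit)
- compound 3 `CN(C)c1ccc(/C=C/c2ccc3ccccc3c2)cc1`: 3660 nM

Compound 1 has no number of its own. It stands at the limit of > 5000 nM in this assay, at which 2 of the 3 values shown sit, alongside compound 2.

Compound 4 `COc1ccc(/C=C/c2ccc3ccccc3c2)cc1N` keeps the core and the methoxy group of compound 1 and differs by amino in place of hydrogen on an aromatic carbon, ortho to a methoxy group.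

Within the data shown here, no measured step adds a group at this place, so the evidence is indirect. Two steps replace the methoxy group instead. One is a step that the two limits leave unreadable from compound 1 to compound 2, which gives no usable size. Among the measured compounds shown here, the other is an at least 1.3-fold lower number from compound 1 to compound 3 (0.13 log units; that floor lies within the scatter), the only step with a readable direction, and it concerns a different nitrogen-bearing group at a different place.

On that slender basis, a modest shift towards stronger inhibition in this assay is expected, and another limit remains possible. The expected change is an estimated at least 2.0-fold lower number from compound 1 to compound 4 (0.30 log units; that floor lies within the scatter). Compound 4 is estimated at 2500 nM, with an expected range of 500 nM to 8000 nM.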

Compound 4, half-maximal inhibitory concentration: > 5000 nM
Compound 4 gave a limit, no number; the forecaster's own chance of this, stated with the estimate: 35%; middle value at least 2.0-fold (0.30 log units) from the limit.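

Compound 4, like compound 1, stands at a limit and not at a number in this assay, so the step from compound 1 to compound 4 cannot be read: the limit of > 5000 nM in this assay, at which 3 of the 4 values shown sit.

The compounds shown leave open whether amino in place of hydrogen on an aromatic carbon changes inhibition at all, and in which direction.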